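Chloro for methoxy on the aryl-thiazole arm of the series

The source may hold more compounds than are shown below. What is called first, only, known or untested is meant among the compounds shown, and "the series" means these compounds.

Measured so far:
compound 1 `COc1ccc(-c2nc(C)c(C(=O)CSc3nc(N)c(C#N)c(-c4ccccc4)n3)s2)cc1` gives 5.25%
compound 2 `COc1ccc(-c2nc(C)c(C(=O)CSc3nc(N)c(C#N)c(-c4ccc(OC)cc4)n3)s2)cc1` gives 0.26%

Both values come from a functional assay on U-87MG ATCC cells for antiproliferative activity against U-87 MG (Homo sapiens), read by MTT assay, with a stated time of 48 h, tested at 100 uM; a higher number here means a weaker effect of the compound at the concentration tested, a lower number a stronger effect. Compound 1 stands highest of the two numbers, and its nearest neighbour is compound 2, with the step of a number 5 percentage points lower from compound 1 to compound 2 (within the scatter); the two compounds are thus not separable on this read-out. Compound 3 `Cc1nc(-c2ccc(Cl)cc2)sc1C(=O)CSc1nc(N)c(C#N)c(-c2ccccc2)n1` is not yet measured. It differs from compound 1 by chloro in place of methoxy on an aromatic carbon: methoxy leaves, chloro enters, on an aromatic carbon of a six-membered aromatic ring of carbon only, so that 4-methoxyphenyl becomes 4-chlorophenyl. Going by the values given here, the one measured step, from compound 1 to compound 2, concerns a methoxy on the other aryl ring and was within the scatter; no measured step bears directly on the exchange of methoxy for chloro. With both measured compounds near the floor of the read-out, compound 3 is expected to stay in the same region, and the expected step of a number 0.3 percentage points lower from compound 1 to compound 3 (within the scatter) is none beyond the scatter. Compound 3 is therefore estimated at 5%, with a range from 0% to 20%.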

Compound 3, a percentage reported as activity, at one concentration (the size of the read-out at that concentration, not a potency): 4.59%
The estimate for compound 3 lay 0.4 percentage points above the measured number; the measured number falls inside the stated range.
By their numbers in this assay, from the lowest: compounds 2, 3 and 1 (each within the scatter of the next).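

In this assay, the exchange of 4-methoxyphenyl for 4-chlorophenyl gives a number 0.7 percentage points lower from compound 1 to compound 3 (within the scatter). Going by these compounds alone, this is the first reading at this position, as the earlier step concerned a methoxy on the other aryl ring, and it shows that the read-out of the series does not depend on the methoxy here: chloro, para to a large group, serves equally well on this read-out, with compound 3 at 4.59%. The data give no measured property of either group and nothing that could explain why the exchange leaves the read-out within the scatter.

Still open is whether this tolerance extends beyond the two groups shown, for example to an amine or a carboxylic acid on the same aromatic carbon, or to a longer chain such as butoxy in place of methoxy. Also open, on these data alone, is whether compound 1 and compound 3 would separate at lower concentrations, since a read-out at one concentration gives the size of the effect there and not a potency.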